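From 2-hydroxyethyl to 3-hydroxypropyl in compound 4

This account rests on a few compounds, and the source may have more. Where it says the series, first, only, none or still open, it means among the compounds named here.

- Compound 1 `NS(=O)(=O)c1ccc(S(=O)(=O)CCCO)cc1` gives 7200 ug/mL
- Compound 2 `NS(=O)(=O)c1ccc(SCCCO)c(Cl)c1` gives 280 ug/mL
- Compound 3 `NS(=O)(=O)c1ccc(SCCO)c(F)c1` gives 6000 ug/mL

These three numbers all come from a physicochemical assay for solubility, at pH 7.4 (on this read-out higher numbers stand for higher solubility and lower numbers for lower solubility), and they split into two groups. Compound 3 at 6000 ug/mL lies within the usual scatter of compound 1 at 7200 ug/mL and so the two cannot be told apart. Compound 2 at 280 ug/mL sits far lower than both, well beyond the scatter.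

Compound 4 `NS(=O)(=O)c1ccc(SCCCO)c(F)c1` is the next to be measured. It departs from compound 3 in one place, with hydroxymethyl in place of hydroxy on a saturated chain carbon, two bonds along the chain from a sulfur. Read one bond further out, this turns (2-hydroxyethyl)sulfanyl into (3-hydroxypropyl)sulfanyl.

Going by the values given here, no two measured compounds differ in one place only, so no measured step gauges this change. The nearest hint is compound 2 at 280 ug/mL which shares the (3-hydroxypropyl)sulfanyl group with compound 4 but differs from it elsewhere too. A modest fall is therefore expected in this assay with an estimated 2.4-fold lower number from compound 3 to compound 4 (0.38 log units; beyond the scatter) that may sit close to the edge of the scatter. For compound 4 the estimated value is 2500 ug/mL with an expected range from 800 ug/mL to 7000 ug/mL on this estimate.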

Compound 4, solubility: 900 ug/mL
For compound 4 the middle estimate is 2.8-fold (0.44 log units) above the measured one; the range from low to high includes it.
By their numbers in this assay, from the lowest: compound 2; then compound 4; then compounds 3 and 1 (each within the scatter of the next).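

In this assay, the step from (2-hydroxyethyl)sulfanyl to (3-hydroxypropyl)sulfanyl now has a measured size (a 6.7-fold lower number from compound 3 to compound 4 (0.82 log units; beyond the scatter)), and it lies beyond the scatter, so even hydroxymethyl in place of hydroxy at this saturated chain carbon registers clearly on this read-out. The halogen matters as well: with the (3-hydroxypropyl)sulfanyl group held constant, fluoro in place of chloro on an aromatic carbon gives a step that also lies beyond the scatter, in the opposite direction (a 3.2-fold higher number from compound 2 to compound 4 (0.51 log units; beyond the scatter)). These two steps give sizes and directions only, and no measurement shown here offers an explanation for either of them.

The compounds shown pair the 2-hydroxyethyl chain only with fluoro, so it remains open whether the same chain step would appear with chloro on the aromatic carbon. Also open, on these data alone, is how this read-out would respond to a longer chain such as 4-hydroxybutyl, or to an amine or a carboxylic acid in place of the hydroxy.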